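Dropping a Methyl: Expected Stability of Compound 3

The source may report more compounds than this note shows. Statements on the series, on what has been measured and on what is new or still open speak of the compounds shown alone.

Compound 1 `Cc1ccccc1S(=O)(=O)c1ccc(CNC(=O)c2cc3cnccc3[nH]2)cc1`: 48%
Compound 2 `O=C(NCc1ccc(S(=O)(=O)c2cccc(C(F)(F)F)c2)cc1)c1cnc2nccn2c1`: 41%

Both compounds were tested in an ADME assay on microsomes from liver (Homo sapiens) for metabolic stability, read by LC-MS, with a stated time of 30 min, tested at 1 uM; on this read-out higher numbers stand for a more stable compound and lower numbers for a less stable compound. Compound 1 gives 48% and compound 2 gives 41%. Of the two, compound 1 has the larger reading, yet the gap to compound 2 falls within the usual scatter of such measurements, so the two compounds cannot be separated on these numbers. They also differ in several parts of their structures at once, so no single change can be tied to that gap.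

Compound 3 `O=C(NCc1ccc(S(=O)(=O)c2ccccc2)cc1)c1cc2cnccc2[nH]1` has not yet been measured in this assay. It differs from compound 1 in one place: hydrogen in place of methyl on an aromatic carbon. The methyl that leaves sits on the ring ortho to a large group, and the rest of the molecule is unchanged. Within the data shown here, no measured pair shows what such a change does here, so the only anchor is compound 1 itself.

With so small a change, a step no larger than the scatter seems most likely, in either direction. For compound 3 the expected step is a number 3 percentage points lower from compound 1 to compound 3 (within the scatter). The estimate for compound 3 in this assay is 45%, with a likely range from 25% to 65%.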

Compound 3, percent of the compound remaining: 75%
The estimate for compound 3 lay 30 percentage points below the measured number; measured number above the stated range.
By their numbers in this assay, from the lowest: compounds 2 and 1 (each within the scatter of the next); then compound 3.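

In this assay, the change from 2-methylphenyl to phenyl gives a number 27 percentage points higher from compound 1 to compound 3 (beyond the scatter). Compound 1 and compound 2 differ in several places at once, so they could not tie any reading to one part of the structure, whereas this pair differs in one place only and shows that this position matters: a single methyl on an aromatic carbon, ortho to a large group, is enough to move the reading past the usual scatter. Nothing shown here explains why the reading rises, as no measurement bears on the cause of this step.

As far as these compounds go, this is one pair on one core, so it remains open whether hydrogen is the best choice at this place or whether a fluorine atom, a chlorine atom or a methoxy group would give a similar reading or a different one. From the compounds shown here alone, it also remains open whether the same step would appear on the core of compound 2, where the sulfonyl-bound ring carries a trifluoromethyl group instead of a methyl.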